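A few compounds are considered here, and "the series" means these few. Any claim that something is new, unique, unknown or untested is made for them only; others in the source may bear on it.

Going by the values given here, compound 3 `COc1ccc2c(=O)c(C(=O)NCCC3CCN(Cc4ccccc4)CC3)coc2c1` is one of three compounds so far measured in an assay on isolated protein for inhibition of Amine oxidase [flavin-containing] B (Homo sapiens), read by fluorescence and Amplex Red, with stated times of 15 min and 20 min; a lower number here means a stronger inhibitor, a higher number a weaker inhibitor. In this assay compound 3 gives 30900 nM, the second highest of the three numbers. Its nearest companion is compound 2 `O=C(NCCC1CCN(Cc2ccccc2)CC1)c1coc2ccccc2c1=O`, which in this assay gives 35300 nM; the two lie within the scatter of each other. The furthest is compound 1 `O=C(NC1CCN(Cc2ccccc2)CC1)c1coc2cc(Br)ccc2c1=O`, which in this assay gives 19700 nM, and this too is within the scatter of compound 3. Among the compounds with values here, the one step that joins two measured compounds differing at a single place, a 1.1-fold lower number from compound 2 to compound 3 (0.06 log units; within the scatter), comes with methoxy in place of hydrogen on an aromatic carbon and moves nothing beyond the scatter.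

Compound 4 `O=C(NCCC1CCN(Cc2ccccc2)CC1)c1coc2cc(Br)ccc2c1=O` has not yet been measured. It differs from compound 3 in one place: bromo in place of methoxy on an aromatic carbon. Within the data shown here, no measured step swaps these two groups directly. Among the measured compounds shown here, compound 1 carries the same bromo group, but it differs from compound 4 in more than one place, and its value shows only that a bromo compound of this series sits in the same broad region as compound 2 and compound 3. For the measured compounds named here, with the single measured step lying within the scatter, no step beyond the scatter is expected here. The estimate for compound 4 is a step of a 1.2-fold lower number from compound 3 to compound 4 (0.09 log units; within the scatter), giving an expected value of 25000 nM, with a range from 10000 nM to 60000 nM.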

Compound 4, half-maximal inhibitory concentration: 29500 nM
Estimate against measurement, compound 4: 1.2-fold (0.07 log units) below; low and high end bracket the measured number.
By their numbers in this assay, from the lowest: compounds 1, 4, 3 and 2 (each within the scatter of the next).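

In this assay, the bromo group on this aromatic carbon can now be set against both of the other groups shown there: the swap for methoxy gives a 1.0-fold lower number from compound 3 to compound 4 (0.02 log units; within the scatter), and the swap for hydrogen gives a 1.2-fold lower number from compound 2 to compound 4 (0.08 log units; within the scatter). Together with the earlier methoxy step, this means that hydrogen, methoxy and bromo at this one carbon all lie within the scatter of each other, although the two substituents differ in their atoms and only methoxy counts a hydrogen-bond acceptor; among compounds 2, 3 and 4, none goes against this flat picture. Nothing available here explains this flat result.

The compounds shown cannot tell whether this carbon would stay just as insensitive with a very different group on it, such as an amine or a carboxylic acid, since all three groups compared carry no net charge. They also leave open whether a longer chain between the amide nitrogen and the ring carrying the benzyl group, or a substituent on the benzyl group itself, would move the number beyond the scatter.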